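The source may hold more compounds than are shown below. What is called first, only, known or untested is meant among the compounds shown, and "the series" means these compounds.

Measured so far in a functional assay on the whole organism (strain Wistar) for inhibition, with Rattus norvegicus as the target, read by paw edema, with stated times of 30 min and 2 h, at a dose of 50 mg/kg by the oral route; a lower number here means less inhibition, a higher number more inhibition at the dose given (going by the name of the read-out):
- compound 1 `Nc1cc(-c2ccc(Cl)cc2)nc2cc(-c3ccccc3)nn12` gives 13.8%
- compound 2 `Cc1ccc(-c2cc3nc(-c4ccc(Cl)cc4)cc(N)n3n2)cc1` gives 67.5%

Going by the values given here, compound 2 holds the higher of the two numbers in this assay; its only neighbour is compound 1, and the step of a number 53.7 percentage points higher from compound 1 to compound 2 (beyond the scatter) is large. Compound 3 `Nc1cc(-c2ccc(Cl)cc2)nc2cc(-c3ccc(Br)cc3)nn12` differs from compound 2 by bromo in place of methyl on an aromatic carbon. Among the compounds with values here, the single measured step bears only indirectly: it tells what a methyl adds over hydrogen, not how bromo compares with methyl, so no measured pair covers the present change. For compound 3 the step is estimated as a number 15.5 percentage points lower from compound 2 to compound 3 (beyond the scatter), a modest fall with wide uncertainty. Compound 3 is expected at 52%, range 25% to 75%.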

Compound 3, a percentage reported as inhibition, in the whole organism at one dose (the size of the read-out at that dose, not a potency): 72.5%
For compound 3 the middle estimate is 20.5 percentage points below the measured one, within the range that was stated.
By their numbers in this assay, from the lowest: compound 1; then compounds 2 and 3 (each within the scatter of the next).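

Changing 4-methylphenyl to 4-bromophenyl gives, in this assay, a number 5 percentage points higher from compound 2 to compound 3 (within the scatter), so this position does not separate methyl from bromo. Bromo in place of hydrogen gives a number 58.7 percentage points higher from compound 1 to compound 3 (beyond the scatter), so the large rise is no longer tied to methyl alone but is shared by two different groups on this aromatic carbon. No measurement offered here explains this result.

Open, as far as these compounds go, is whether a methoxy group, an amine or a carboxylic acid at the same place would hold the inhibition. Also open, from the compounds shown here alone, is whether the chloro on the other aromatic ring contributes to it.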